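The source may hold more compounds than are shown below. What is called first, only, known or untested is meant among the compounds shown, and "the series" means these compounds.

Series notes on cytotoxicity toward HFF cells. Compound 1 `CSc1nc(Cl)c2ccn(COCCOC(C)=O)c2n1` gives 100000 nM in a functional assay on HFF cells (Homo sapiens) for cytotoxicity; on this read-out higher numbers stand for weaker inhibition and lower numbers for stronger inhibition. Compound 2 `CS(=O)(=O)c1nc(N)c2ccn(COCCO)c2n1` reaches only a limit of the assay, > 100000 nM, in this assay. Compound 2 thus sits at the limit of > 100000 nM in this assay, at which 1 of the 2 values shown sits. Compound 3 `Nc1nc(N)c2ccn(COCCO)c2n1` carries amino in place of methylsulfonyl on an aromatic carbon, amino in place of methylsulfonyl on an aromatic carbon. For the measured compounds named here, no measured step between compounds of this kind is available, so the step of a number no higher from compound 2 to compound 3 (the limit leaves the size open) is expected to stay within the scatter, with no shift beyond it. Compound 3 is therefore expected to give about 100000 nM, within 30000 nM to 300000 nM, most likely reported again as a limit.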

Compound 3, half-maximal inhibitory concentration: > 100000 nM
Compound 3 gave a limit, no number (the forecaster's own chance of this, stated with the estimate: 70%); the middle value sits exactly at the limit.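

Compound 2 and compound 3 both stand only as limits of the assay, so no step can be read from this pair: the limit of > 100000 nM in this assay, at which 2 of the 3 values shown sit.

The compounds shown leave open whether amino in place of methylsulfonyl on an aromatic carbon changes cytotoxicity at all.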